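The source may report more compounds than this note shows. Statements on the series, on what has been measured and on what is new or still open speak of the compounds shown alone.

Among the measured compounds shown here, compound 2 `CNC(=O)c1cc(Oc2ccc(C(=O)/C=C/c3cccc(Br)c3)cc2)ccn1` is the one compound of this set for which a result is given. In a functional assay on A549 cells (Homo sapiens) for cytotoxicity, read by MTT assay, with a stated time of 72 h (a higher number here means a weaker inhibitor, a lower number a stronger inhibitor), compound 2 gives 9940 nM. Compound 1 `CNC(=O)c1cc(Oc2ccc(/C=C/C(=O)c3ccc([N+](=O)[O-])cc3)cc2)ccn1` belongs to the same set, but in this assay compound 1 gives "not determined" (no result reported), so compound 2 stands alone: its value is the only number shown, and no comparison among measured compounds can be drawn from it.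

Compound 3 `CNC(=O)c1cc(Oc2ccc(C(=O)/C=C/c3ccc([N+](=O)[O-])cc3)cc2)ccn1` differs from compound 2 in one place, (4-nitrophenyl in place of 3-bromophenyl on a double-bonded chain carbon bound to a double-bonded chain carbon). For the measured compounds named here, because no pair of measured compounds differs in a single place, the size of such a step cannot be read from the data; the one number available gives no sense of direction. The expectation for compound 3 is therefore a step from compound 2 that is small, in the direction of a somewhat stronger inhibitor, but of a size that may well lie within the usual scatter, which would be a 1.4-fold lower number from compound 2 to compound 3 (0.15 log units; within the scatter). On that basis compound 3 is estimated to give 7000 nM in this assay, within a range from 2500 nM to 20000 nM.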

Compound 3, half-maximal inhibitory concentration: > 50000 nM
Compound 3 ended at the assay's limit; the forecaster's own chance of this, stated with the estimate: 10%; middle value at least 7.1-fold (0.85 log units) from the limit.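

In this assay, the place on a double-bonded chain carbon bound to a double-bonded chain carbon proves sensitive to what it carries: 4-nitrophenyl in place of 3-bromophenyl gives an at least 5.0-fold higher number from compound 2 to compound 3 (0.70 log units; beyond the scatter). Among the compounds shown here, this is the first step in the set that can be read at all, and it lies beyond the scatter, so the two aryl groups cannot be treated as equivalent at this place in this cytotoxicity read-out. Compound 3 stands at a limit of the assay and not at a number, so the step gives only a minimum size, with its full extent unknown: the limit of > 50000 nM in this assay, at which 1 of the 3 values shown sits.

Both the group and its ring position differ between compound 2 and compound 3, so this single step cannot separate the effect of swapping bromine for nitro from that of moving the group, and compound 1, which also carries 4-nitrophenyl, has no result to add. From the compounds shown here alone, how an unsubstituted phenyl, or a phenyl carrying an amine or a carboxylic acid, would behave at this place remains open.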